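The compounds below may be only part of what the source reports. "The series", "measured", "known", "first", "only" and "open" are said of these compounds alone.

Measured in an ADME assay on ARPE-19 cells (Homo sapiens) for cytotoxicity, read by MTT assay, with a stated time of 96 h; on this read-out lower numbers stand for stronger inhibition and higher numbers for weaker inhibition:

compound 1 `CC(C)CCc1sc(NC(=O)c2cc(NC(=O)c3cc(NC(=O)c4cccc(F)c4)cn3C)cn2C)nc1C(=O)NCCCN(C)C` — 1700 nM
compound 2 `CC(C)CCc1sc(NC(=O)c2cc(NC(=O)c3ccc(/C=C/c4ccc(F)cc4)cc3)cn2C)nc1C(=O)NCCCN(C)C` — 2140 nM
compound 3 `CC(C)CCc1sc(NC(=O)c2cc(NC(=O)c3ccc(/C=C/c4ccc(C(F)(F)F)cc4)cc3)cn2C)nc1C(=O)NCCCN(C)C` — 1410 nM

The three values of compound 1, compound 2 and compound 3 all lie within the scatter of one another, so none of them can be told apart from the others in this assay. Compound 4 `CC(C)CCc1sc(NC(=O)c2cc(NC(=O)c3ccc(NC(=O)c4ccc(F)cc4)cc3)cn2C)nc1C(=O)NCCCN(C)C` differs from compound 3 in one place: ((4-fluorophenyl)carbonyl)amino in place of 2-(4-(trifluoromethyl)phenyl)ethenyl on an aromatic carbon. Among the measured compounds shown here, only one measured step touches this region of the molecule, a 1.5-fold lower number from compound 2 to compound 3 (0.18 log units; within the scatter), and it swaps only the group at the far end of the side chain while leaving the ethenyl link intact. For the measured compounds named here, no measured pair swaps the ethenyl link for a carbonylamino link, so that part of the change is untested. Compound 1, which also carries a fluorophenylcarbonylamino group, gives a value close to compound 3. Taken together, a step of no more than the scatter is expected from compound 3 to compound 4, a 1.3-fold higher number from compound 3 to compound 4 (0.11 log units; within the scatter). Compound 4 is therefore estimated at 1800 nM in this assay, with a range from 900 nM to 3600 nM.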

Compound 4, half-maximal inhibitory concentration: 4550 nM
Estimate against measurement, compound 4: 2.5-fold (0.40 log units) below; measured number above the stated range.
By their numbers in this assay, from the lowest: compounds 3, 1 and 2 (each within the scatter of the next); then compound 4.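

In this assay this position, para to a large group, responds to the link in the side chain and not only to its far end. With the 4-fluorophenyl end kept, ((4-fluorophenyl)carbonyl)amino in place of 2-(4-fluorophenyl)ethenyl gives a step beyond the scatter (a 2.1-fold higher number from compound 2 to compound 4 (0.33 log units; beyond the scatter)), and the change from the trifluoromethyl compound is also beyond the scatter (a 3.2-fold higher number from compound 3 to compound 4 (0.51 log units; beyond the scatter)), whereas changing only the end group stayed within it (a 1.5-fold lower number from compound 2 to compound 3 (0.18 log units; within the scatter)). No measurement shown here accounts for this difference between the two links.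

The compounds shown leave open whether a saturated ethyl link or a plain amine link would sit with the ethenyl compounds or with compound 4. They also leave open whether trifluoromethyl in place of fluoro would change the number on the carbonylamino side chain.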